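The compounds below may be only part of what the source reports. "The series", "measured", "known", "first", "only" and "open" are said of these compounds alone.

Measured compounds:
- compound 2, `Cc1ccc(NC(=S)OCCc2ccncc2)cc1`: > 100000 nM
- compound 1, `O=[N+]([O-])c1ccc(NC(=S)OCCc2ccccn2)cc1`: > 100000 nM

Both were tested in an ADME assay on MT4 cells (Homo sapiens) for cytotoxicity, read by MTT assay; on this read-out higher numbers stand for lower toxicity in this test and lower numbers for higher toxicity in this test. For compound 2 the reading > 100000 nM is a limit of the assay and not a number. For compound 1 the reading > 100000 nM is likewise a limit. Compound 2 therefore stands at the limit of > 100000 nM in this assay, at which 2 of the 2 values shown sit, so no ordering among the measured compounds can be drawn from these readings.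

Compound 3, `O=[N+]([O-])c1ccc(NC(=S)OCCc2ccncc2)cc1`, is the next compound and has not yet been measured. It differs from compound 2 in one place: nitro in place of methyl on an aromatic carbon. Because compound 1 already carries nitro and sits at the limit of > 100000 nM in this assay, at which 2 of the 2 values shown sit, no step beyond the usual scatter is expected from this change, in either direction. The step from compound 2 to compound 3 in this assay is estimated as a step that the limit leaves unreadable from compound 2 to compound 3. For compound 3 the expected reading is 150000 nM, with a range from 50000 nM to 500000 nM, most probably reported again as a limit.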

Compound 3, half-maximal cytotoxic concentration: > 100000 nM
Compound 3: a limit, no number (the forecaster's own chance of this, stated with the estimate: 80%); the middle value does not contradict the limit.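

In this assay compound 3 gives > 100000 nM, which is a limit and not a number. Going by these compounds alone, no step from compound 1 or compound 2 to compound 3 can therefore be read. The compounds shown leave open whether nitro in place of methyl, or pyridin-4-yl in place of pyridin-2-yl, changes this reading at all.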